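The source may hold more compounds than are shown below. What is called first, only, known or untested is meant among the compounds shown, and "the series" means these compounds.

Measured in a functional assay on K562 cells (Homo sapiens) for antiproliferative activity, with a stated time of 72 h; on this read-out higher numbers stand for weaker inhibition and lower numbers for stronger inhibition:
- compound 1 `OC[C@H]1O[C@@H](n2cnc3c(NCc4ccc(Cl)cc4)ncnc32)[C@H](O)[C@@H]1O`: 218000 nM
- compound 2 `OC[C@H]1O[C@@H](n2cnc3c(NCc4cc(O)cc(O)c4)ncnc32)[C@H](O)[C@@H]1O`: > 166000 nM (a limit of the assay, not a number)

Compound 2 carries no number, only a limit: the limit of > 166000 nM in this assay, at which 1 of the 2 values shown sits. Compound 3 `Cc1cccc(CNc2ncnc3c2ncn3[C@@H]2O[C@H](CO)[C@@H](O)[C@H]2O)c1O` keeps the shared core and changes only the aryl group on the chain carbon: 2-hydroxy-3-methylphenyl in place of 3,5-dihydroxyphenyl on a saturated chain carbon bound to a nitrogen on an aromatic ring. The same change reads 3,5-dihydroxybenzyl to 2-hydroxy-3-methylbenzyl.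

Going by the values given here, one measured step bears on this position, a step that the limit leaves unreadable from compound 1 to compound 2, and its size cannot be read. Among the compounds with values here, no measured compound carries the 2-hydroxy-3-methylphenyl group, so there is no measured size to carry over. Within the data shown here, the only firm number in this assay is that of compound 1 at 218000 nM, so the expectation for compound 3 stays in that weak region, with the range left wide and open toward stronger inhibition. The expected step, modest and toward stronger inhibition, is an at least 2.0-fold lower number from compound 2 to compound 3 (0.31 log units; beyond the scatter). Compound 3 is estimated at 80000 nM, with an expected range of 8000 nM to 220000 nM.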

Compound 3, half-maximal inhibitory concentration: 18000 nM
Compound 3: middle estimate off by 4.4-fold (0.65 log units), on the high side, within the range that was stated.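

In this assay, the aryl group on the saturated chain carbon bound to a nitrogen on an aromatic ring proves able to shift the read-out well beyond the scatter: 2-hydroxy-3-methylphenyl in place of 4-chlorophenyl gives a 12-fold lower number from compound 1 to compound 3 (1.08 log units; beyond the scatter). Going by these compounds alone, in place of 3,5-dihydroxyphenyl, the same group gives an at least 9.2-fold lower number from compound 2 to compound 3 (0.96 log units; beyond the scatter), so the first step at this position with a firm size is the one between the two measured ends, while this second step has only a lower bound. The step from compound 1 to compound 2 cannot be read, and compound 2 stands only as a limit of the assay, not a number: the limit of > 166000 nM in this assay, at which 1 of the 3 values shown sits.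

On these data alone, whether the hydroxy or the methyl of the 2-hydroxy-3-methylphenyl group carries the shift stays open, as does how an aryl group bearing an amine or a carboxylic acid, or a longer chain between the ring and the nitrogen, would read in this assay. As far as these compounds go, compound 3 gives 18000 nM, and also open is whether any group at this place takes the number much further down.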